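Chloro for trifluoromethyl at the fused aromatic ring

The source may hold more compounds than are shown below. What is called first, only, known or untested is meant among the compounds shown, and "the series" means these compounds.

The account concerns two measured compounds and one not yet measured. Compound 1 `COc1cc2c(Nc3cnc(OCCCC4CCCC4)nc3)ncnc2cc1OCCCN1CCCCC1` gives 2 uL/min in an ADME assay on cells (Hepatocyte, Rattus norvegicus) for metabolic stability; a lower number here means slower removal, a higher number faster removal of the compound. Compound 2 `CNC(=O)c1sc(N2CC3CC2(CNC(=O)c2c[nH]c4ncc(C(F)(F)F)cc24)C3)nc1C(F)(F)F` gives 78 uL/min in this assay, which is the higher of the two numbers; the gap to compound 1 is beyond the usual scatter, and nothing in the data accounts for it. Compound 3 `CNC(=O)c1sc(N2CC3CC2(CNC(=O)c2c[nH]c4ncc(Cl)cc24)C3)nc1C(F)(F)F` has not been measured in this assay. It differs from compound 2 in one place: chloro in place of trifluoromethyl on an aromatic carbon, on an aromatic carbon of a six-membered aromatic ring with one nitrogen, part of a fused system of two rings. Among the compounds with values here, no measured pair shows this change, so the expected step from compound 2 to compound 3, a 1.0-fold lower number from compound 2 to compound 3 (0.02 log units; within the scatter), is expected to stay within the scatter in this assay. Compound 3 is therefore estimated at 75 uL/min, with a range from 35 uL/min to 160 uL/min.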

Compound 3, intrinsic clearance in a liver preparation (reported as CLH), per the amount of preparation that the assay uses in the Hepatocyte assay: 120 uL/min
Estimate against measurement, compound 3: 1.6-fold (0.20 log units) below; the measured number falls inside the stated range.
By their numbers in the Hepatocyte assay, from the lowest: compound 1; then compounds 2 and 3 (each within the scatter of the next).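

Within the data shown here, in the Hepatocyte assay the change of trifluoromethyl to chloro on this aromatic carbon of the fused system gives a 1.5-fold higher number from compound 2 to compound 3 (0.19 log units; within the scatter) and so provides the first reading at this position, where the two groups cannot be told apart in this assay. In a physicochemical assay for lipophilicity, at pH 7.4 (a higher number here means a more lipophilic compound, a lower number a more polar compound), compound 2 gives 4.2 and compound 3 gives 4 with the pair lying within the scatter, so neither assay separates the two compounds. No measurement at hand offers a reason for these readings.

On these data alone, both groups at this carbon carry no hydrogen-bond donor or acceptor, so it remains open how a nitrile or an amine in the same place would read in either assay. Whether any replacement here can move the number in the Hepatocyte assay beyond the scatter also stays unanswered.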